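Repeating a Small Methyl Step on a Second Core

The source may hold more compounds than are shown below. What is called first, only, known or untested is meant among the compounds shown, and "the series" means these compounds.

Three compounds share one core. Compound 1 `COc1cc2c(Nc3ccc(C#N)cc3)ncnc2cc1OCCCN1CCCCC1` gives 24400 nM in a functional assay on DU-145 cells (Homo sapiens) for antiproliferative activity, read by MTT assay, with a stated time of 72 h; a lower number here means a stronger inhibitor, a higher number a weaker inhibitor. Compound 2 `COc1cc2c(Nc3ccc(C#N)cc3)ncnc2cc1OCCCN1CCC(C)CC1` carries methyl in place of hydrogen on a saturated ring carbon and gives 16600 nM; that step is a 1.5-fold lower number from compound 1 to compound 2 (0.17 log units; within the scatter). Compound 3 `COc1cc2c(Nc3ccccc3C#N)ncnc2cc1OCCCN1CCCCC1` differs from compound 1 by 2-cyanophenyl in place of 4-cyanophenyl on a nitrogen on an aromatic ring; in this assay compound 3 gives 15300 nM, and that step is a 1.6-fold lower number from compound 1 to compound 3 (0.20 log units; within the scatter). All three numbers lie within the usual scatter of one another, so no order among them can be claimed.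

Compound 4 `COc1cc2c(Nc3ccccc3C#N)ncnc2cc1OCCCN1CCC(C)CC1` has not yet been measured. It differs from compound 3 by methyl in place of hydrogen on a saturated ring carbon, the same change as from compound 1 to compound 2, at a place described in identical terms. Because the earlier step was a 1.5-fold lower number from compound 1 to compound 2 (0.17 log units; within the scatter), the step from compound 3 to compound 4 is expected to be a 1.5-fold lower number from compound 3 to compound 4 (0.16 log units; within the scatter). Compound 4 is therefore estimated at 10500 nM, most likely between 4500 nM and 25000 nM.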

Compound 4, half-maximal inhibitory concentration: 11900 nM
The estimate for compound 4 lay 1.1-fold (0.05 log units) below the measured number; measured number inside the range.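

In this assay, going from piperidin-1-yl to 4-methylpiperidin-1-yl gives a 1.3-fold lower number from compound 3 to compound 4 (0.11 log units; within the scatter), and the swap between the two cyanophenyl groups gives a 1.4-fold lower number from compound 2 to compound 4 (0.14 log units; within the scatter); both steps are too small to show that either change moves the number at all. Within the data shown here, what can be said is only that the methyl step looks alike on both cores: the same change on two cores in this assay, a 1.5-fold lower number (0.17 log units; within the scatter) from compound 1 to compound 2 and a 1.3-fold lower number (0.11 log units; within the scatter) from compound 3 to compound 4, 1.1-fold (0.06 log units) apart, within the scatter of two such steps. The same holds for the cyanophenyl swap: the same change on two cores in this assay, a 1.6-fold lower number (0.20 log units; within the scatter) from compound 1 to compound 3 and a 1.4-fold lower number (0.14 log units; within the scatter) from compound 2 to compound 4, 1.1-fold (0.06 log units) apart, within the scatter of two such steps.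

The compounds shown leave open whether a different group in place of 4-methylpiperidin-1-yl, such as morpholin-4-yl or a piperidine bearing a carboxylic acid, would give a step beyond the scatter. They also leave open whether so large a step would carry from one core to the other.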